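The source may report more compounds than this note shows. Statements on the series, on what has been measured and on what is new or still open speak of the compounds shown alone.

Measured so far in an ADME assay on HepG2 2.2.15 cells (Homo sapiens) for cytotoxicity, read by luminescence, with a stated time of 3 days; on this read-out lower numbers stand for higher toxicity in this test and higher numbers for lower toxicity in this test
- compound 1 `COC1COCCN(S(=O)(=O)c2cc(C(=O)Nc3ccc(F)c(Cl)c3)ccc2F)C1` gives 8700 nM
- compound 2 `O=C(Nc1ccc(F)c(Cl)c1)c1ccc(F)c(S(=O)(=O)N2CCCCCCC2O)c1` gives 7000 nM
- compound 3 `O=C(Nc1ccc(F)c(Cl)c1)c1ccc(F)c(S(=O)(=O)N2CCOC[C@@H](O)C2)c1` gives 14000 nM

Compound 3 at 14000 nM lies within the scatter of both other compounds, so these three values do not separate. The next compound is compound 4 `CC1(O)CCCCN(S(=O)(=O)c2cc(C(=O)Nc3ccc(F)c(Cl)c3)ccc2F)C1`, which has 3-hydroxy-3-methylazepan-1-yl in place of 6-hydroxy-1,4-oxazepan-4-yl on a sulfonyl sulfur, and the counted change is 3-hydroxy-3-methylazepan-1-yl in place of 6-hydroxy-1,4-oxazepan-4-yl on a sulfonyl sulfur for this swap.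

Within the data shown here, three measured steps bear on it. The swap of groups on the sulfonyl sulfur gives a 2.0-fold higher number from compound 2 to compound 3 (0.30 log units; within the scatter) and the other such swap gives a 1.2-fold lower number from compound 1 to compound 2 (0.09 log units; within the scatter) while the change from methoxy to hydroxy gives a 1.6-fold higher number from compound 1 to compound 3 (0.21 log units; within the scatter) and all three stay within the scatter. Among the measured compounds shown here, no measured compound carries 3-hydroxy-3-methylazepan-1-yl, so this change is not isolated by the data. For the measured compounds named here, compound 2 at 7000 nM has a group with the same heavy-atom counts as the one entering compound 4, which draws the expectation towards that value. No step beyond the scatter is expected in this assay for this change.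

The expected step is a 1.6-fold lower number from compound 3 to compound 4 (0.19 log units; within the scatter) and it is estimated to stay within the scatter.

Compound 4 is estimated at 9000 nM with an expected range from 4500 nM to 18000 nM in this read-out.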

Compound 4, half-maximal cytotoxic concentration: 10000 nM
Beside the measured number, compound 4's estimate is 1.1-fold (0.05 log units) below it, and the stated range covers the measured number.
By their numbers in this assay, from the lowest: compounds 2, 1, 4 and 3 (each within the scatter of the next).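

In this assay, 3-hydroxy-3-methylazepan-1-yl on the sulfonyl sulfur gives a 1.4-fold lower number from compound 3 to compound 4 (0.15 log units; within the scatter) and a 1.4-fold higher number from compound 2 to compound 4 (0.15 log units; within the scatter) and a 1.1-fold higher number from compound 1 to compound 4 (0.06 log units; within the scatter) with all three steps within the scatter, so this fourth group does not separate from the earlier three. Replacing 6-hydroxy-1,4-oxazepan-4-yl with 3-hydroxy-3-methylazepan-1-yl keeps the seven-membered non-aromatic ring but changes its hetero atom count and adds a methyl group, and this combined change leaves the number for the compound within the scatter of compound 3. The data give no measured basis for assigning a cause to any of these small steps at this position.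

On these data alone, the four groups all place a non-aromatic ring bearing a hydroxy or methoxy group on the sulfonyl sulfur, so it remains open whether an amine such as piperazine, a carboxylic acid or a longer chain at the same place would give a step beyond the scatter. The compounds shown also leave open whether any change at this position separates in this read-out, and what the opposite stereocentre in the group of compound 3 would give.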